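Catechol versus guaiacol on the shared vinyl-linked core

A few compounds are considered here, and "the series" means these few. Any claim that something is new, unique, unknown or untested is made for them only; others in the source may bear on it.

Among the measured compounds shown here, compound 1 `COc1cc(/C=C/c2nc3cc(Cl)cnc3n(CC(=O)O)c2=O)ccc1O` is the one compound in this set with a number: in a functional assay, read by spectrophotometry, with a stated time of 30 min, tested at 10 uM (a lower number here means a weaker effect, a higher number a stronger effect of the compound at the concentration tested), compound 1 gives 62.3%. Compound 2 `COc1ccc(-c2nc3cccnc3n(CC(=O)O)c2=O)cc1O` has in this assay only "not determined" (no result reported), so it offers no comparison. Compound 3 `O=C(O)Cn1c(=O)c(/C=C/c2ccc(O)c(O)c2)nc2cc(Cl)cnc21` differs from compound 1 by hydrogen in place of methyl on an oxygen on an aromatic ring, that is, methoxy to hydroxy, 4-hydroxy-3-methoxyphenyl to 3,4-dihydroxyphenyl. For the measured compounds named here, no measured pair of this kind exists here, so the step is expected to stay small, with no direction beyond the scatter; the expected step is a number 2.7 percentage points higher from compound 1 to compound 3 (within the scatter). For compound 3 the activity in this assay is expected at 65%, within 45% to 85%.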

Compound 3, a percentage reported as activity, at one concentration (the size of the read-out at that concentration, not a potency): 74.7%
For compound 3 the middle estimate is 9.7 percentage points below the measured one, and the stated range covers the measured number.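

In this assay, among the compounds shown here, the change from 4-hydroxy-3-methoxyphenyl to 3,4-dihydroxyphenyl gives a number 12.4 percentage points higher from compound 1 to compound 3 (beyond the scatter), the first readable step, so the methyl on this oxygen is not neutral for the read-out on the shared core. This is a single pair at a single concentration, so it shows a difference in effect size, not in potency. Nothing available bears on why the read-out moves.

Still open, as far as these compounds go, is how an ethyl group on this oxygen, or an amine or fluorine in place of the hydroxy, would compare. From the compounds shown here alone, whether the step carries over to other cores also remains open.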